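Chlorine at the 4-Position of the Phenyl: Compound 4

The source may report more compounds than this note shows. Statements on the series, on what has been measured and on what is new or still open speak of the compounds shown alone.

Measured compounds in an assay on isolated protein for antagonist activity at prostaglandin E2 receptor EP1 subtype (Homo sapiens), read by reporter gene assay; a lower number here means a stronger inhibitor, a higher number a weaker inhibitor:
Compound 1 `O=C(O)c1csc(-n2cc(-c3ccccc3)c3ccccc32)n1`: 120 nM
Compound 2 `O=C(O)c1csc(-n2nc(-c3ccc(F)cc3)c3ccccc32)n1`: 4.5 nM
Compound 3 `O=C(O)c1csc(-n2nc(-c3cccc(F)c3)c3ccccc32)n1`: 20 nM

Compound 3 has the second highest number of the three, with compound 2 lower and compound 1 higher. Compound 4 `O=C(O)c1csc(-n2nc(-c3ccc(Cl)cc3)c3ccccc32)n1` differs from compound 3 in one place: 4-chlorophenyl in place of 3-fluorophenyl on an aromatic carbon. Among the compounds with values here, the one measured step that bears on this is a 4.4-fold higher number from compound 2 to compound 3 (0.65 log units; beyond the scatter), where exchanging 4-fluorophenyl for 3-fluorophenyl raised the number. Compound 4 carries a 4-chlorophenyl, which resembles the 4-fluorophenyl of compound 2 more than the 3-fluorophenyl of compound 3, so a step back toward a lower number is expected. The expected step is a 3.3-fold lower number from compound 3 to compound 4 (0.52 log units; beyond the scatter). Compound 4 is therefore estimated at 6 nM, with a range from 2 nM to 20 nM.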

Compound 4, half-maximal inhibitory concentration: 12 nM
For compound 4 the middle estimate is 2.0-fold (0.30 log units) below the measured one, and the stated range covers the measured number.
By their numbers in this assay, from the lowest: compound 2; then compounds 4 and 3 (each within the scatter of the next); then compound 1.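

In this assay there is a 1.7-fold lower number from compound 3 to compound 4 (0.22 log units; within the scatter) and this stays within the scatter, so 4-chlorophenyl and 3-fluorophenyl cannot be told apart here. With the halogen kept at the 4-position of the phenyl, there is a 2.7-fold higher number from compound 2 to compound 4 (0.43 log units; beyond the scatter) and this shows that the choice of halogen itself modestly changes the number. Nothing measured here explains that difference.

Still open, on these data alone, is how a bromo, methyl or methoxy group at the 4-position of this phenyl would compare. Also open, as far as these compounds go, is how a phenyl carrying no halogen would compare on the core of compound 2.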